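Working notes: hydroxymethyl to fluoromethyl step

The source may report more compounds than this note shows. Statements on the series, on what has been measured and on what is new or still open speak of the compounds shown alone.

compound 1 `Cc1c(F)c(=O)[nH]c(=O)n1C1O[C@H](CO)[C@@H](O)[C@H]1O`: > 10 ug/mL (assay limit)
compound 2 `O=c1cc(CO)n(C2O[C@H](CO)[C@@H](O)[C@H]2O)c(=O)[nH]1`: 98 ug/mL

Among the compounds with values here, in a functional assay on PHA-Ly cells (Homo sapiens) for antiproliferative activity (on this read-out higher numbers stand for weaker inhibition and lower numbers for stronger inhibition), compound 2 at 98 ug/mL holds the only true number in this small set. Compound 1 at > 10 ug/mL is a limit of the assay and not a number.

Compound 3 `O=c1cc(CF)n(C2O[C@H](CO)[C@@H](O)[C@H]2O)c(=O)[nH]1` remains unmeasured. It differs from compound 2 by fluoro in place of hydroxy on a saturated chain carbon bound to an aromatic carbon, which reads as hydroxymethyl to fluoromethyl. Within the data shown here, no measured step in this set sizes such a change, so the expectation starts from compound 2 at 98 ug/mL and stays cautious. A modest move toward stronger inhibition is expected, with the estimated step of a 1.6-fold lower number from compound 2 to compound 3 (0.21 log units; within the scatter) not far beyond the usual scatter. In this assay the estimate for compound 3 is 60 ug/mL with an expected range of 15 ug/mL to 200 ug/mL on this read-out.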

Compound 3, half-maximal inhibitory concentration: > 10 ug/mL
Compound 3: only a limit was reported (the forecaster's own chance of this, stated with the estimate: 30%); the middle value does not contradict the limit.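

In this assay compound 3 gives > 10 ug/mL as a limit of the assay, not a number. The step from compound 2 to compound 3 therefore cannot be read: the limit of > 10 ug/mL in this assay, at which 2 of the 3 values shown sit.
As far as these compounds go, whether hydroxymethyl to fluoromethyl strengthens or weakens inhibition on the shared core stays open.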